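Inverting one chain stereocentre of compound 1

The source may report more compounds than this note shows. Statements on the series, on what has been measured and on what is new or still open speak of the compounds shown alone.

In an ADME assay on Akata cells (Homo sapiens) for cytotoxicity (a higher number here means that more compound is tolerated, a lower number that less compound is tolerated), compound 1 (`Nc1nc2c(ncn2/C=C2/C[C@@H]2[C@@H](O)CO)c(=O)[nH]1`) gives 56000 nM. Compound 2 (`Nc1ncnc2c1ncn2/C=C1/C[C@@H]1[C@H](O)CO`) gives 50500 nM. Among the compounds with values here, these two values lie within the scatter of each other, so compound 1 stands level with the only other measured compound.

Compound 3 (`Nc1nc2c(ncn2/C=C2/C[C@@H]2[C@H](O)CO)c(=O)[nH]1`) has not yet been measured. Its difference from compound 1 is small: the two compounds have the same atoms and bonds and differ only in configuration as drawn: 1 of 3 stereo elements differ; a stereocentre at a saturated chain carbon is drawn R in compound 1 and S in compound 3. A stereocentre at a saturated chain carbon is drawn R in compound 1 and S in compound 3.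

Within the data shown here, no measured pair isolates a change of this kind, so the data offer no direct precedent. No step beyond the scatter is expected in this assay, and the expected outcome is a 1.0-fold lower number from compound 1 to compound 3 (0.01 log units; within the scatter). The estimate for compound 3 is 55000 nM, with an expected range of 28000 nM to 100000 nM.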

Compound 3, half-maximal cytotoxic concentration: 54000 nM
Beside the measured number, compound 3's estimate is 1.0-fold (0.01 log units) above it; measured number inside the range.
By their numbers in this assay, from the lowest: compounds 2, 3 and 1 (each within the scatter of the next).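

In this assay, within the data shown here, the saturated chain carbon now has a direct reading, which the earlier compounds did not give: drawing it S rather than R gives a 1.0-fold lower number from compound 1 to compound 3 (0.02 log units; within the scatter) for this pair. Among these compounds, at this stereocentre, the change of configuration therefore produces no step that can be told apart from the scatter. The pair isolates a single stereo element: the fact that compounds 1 and 3 differ only in the configuration as drawn

The compounds shown leave open whether the other two stereo elements would be equally silent in this assay since only one of the three differs here. They also leave open whether the same flat reading would hold if an amine or a carboxylic acid took the place of a hydroxyl group on the chain, or if a longer chain were attached to the shared core.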